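Acylhydrazone aryl swap: cyanophenyl to aminoethyl pyrrole

The source may hold more compounds than are shown below. What is called first, only, known or untested is meant among the compounds shown, and "the series" means these compounds.

Measured so far:
compound 1 `N#Cc1ccc(/C=N/NC(=O)Nc2ccc(Oc3ccnc4[nH]ccc34)c(F)c2)cc1` 1360 nM
compound 2 `CC(C)(C)c1cc(/C=N/NC(=O)Nc2ccc(Oc3ccnc4[nH]ccc34)c(F)c2)cc(C(C)(C)C)c1O` 13600 nM
compound 3 `O=C(N/N=C/c1ccc(O)cc1Br)Nc1ccc(Oc2ccnc3[nH]ccc23)cc1` 5080 nM

All three compounds share the same core and differ in the aryl group attached to the carbon with a double bond to nitrogen of the acylhydrazone. In a functional assay on A549 cells (Homo sapiens) for antiproliferative activity, read by MTT assay, with a stated time of 72 h (on this read-out lower numbers stand for stronger inhibition and higher numbers for weaker inhibition), compound 1 gives the lowest number of the three; compound 3 stands above it by a margin beyond the scatter, and compound 2 stands furthest above it. Within the data shown here, no pair of measured compounds differs in one place only, so no single step can be read off.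

Compound 4 `CN(C)CCn1cccc1/C=N/NC(=O)Nc1ccc(Oc2ccnc3[nH]ccc23)c(F)c1` takes compound 1 as its point of departure: 1-(2-(dimethylamino)ethyl)-1H-pyrrol-2-yl in place of 4-cyanophenyl on a carbon with a double bond to nitrogen. Nothing measured here reports a pyrrole or a dimethylaminoethyl chain at this position, so the expectation rests only on the spread seen across compounds 1 to 3, in which every change away from compound 1 raised the number. For compound 4 the expected step is therefore a modest rise of a 2.2-fold higher number from compound 1 to compound 4 (0.34 log units; beyond the scatter). For compound 4 in this assay the estimate is 3000 nM, expected to fall between 900 nM and 10000 nM.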

Compound 4, half-maximal inhibitory concentration: "not active" (no number reported)
The entry for compound 4 holds no number; there is nothing to compare the estimate with.
By their numbers in this assay, from the lowest: compound 1; then compound 3; then compound 2.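

In this assay, among these compounds, compound 4 is reported as "not active" with no number, so no step from compound 1 to compound 4 can be read. No available evidence bears on this result. The compounds shown leave open whether the pyrrole ring or the dimethylaminoethyl chain goes with this outcome.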